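Ethyl to Vinyl on a Saturated Chain

The source may hold more compounds than are shown below. What is called first, only, known or untested is meant among the compounds shown, and "the series" means these compounds.

In a functional assay on SK-MEL-28 cells (Homo sapiens) for inhibition, read by colorimetric assay and MTT assay, with a stated time of 72 h (a lower number here means a stronger inhibitor, a higher number a weaker inhibitor), compound 1 `C=CCCCCOc1ccc(OC)cc1-c1cnc(OCCC=C)n1C` gives 62000 nM. Among the measured compounds shown here, in the same test, compound 2 `CCCCOc1ncc(-c2ccccc2OC)n1C` gives 82000 nM, which lies within the usual scatter of the only other measured number, so the two cannot be told apart.

Compound 3 `C=CCCOc1ncc(-c2ccccc2OC)n1C` keeps the shared core of compound 2 and changes one place: vinyl in place of ethyl on a saturated chain carbon, two bonds along the chain from an oxygen on an aromatic ring. For the measured compounds named here, no measured pair shows this change on its own. Compound 1 also carries a (but-3-en-1-yl)oxy group and gives 62000 nM, so no shift beyond the scatter is expected in this assay, in either direction. The expected change is small, an estimated step of a 1.2-fold lower number from compound 2 to compound 3 (0.07 log units; within the scatter). The estimated value for compound 3 is 70000 nM, with an expected range of 35000 nM to 140000 nM.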

Compound 3, half-maximal inhibitory concentration: 21000 nM
Compound 3: middle estimate off by 3.3-fold (0.52 log units), on the high side; measured number outside the range, below it.
By their numbers in this assay, from the lowest: compound 3; then compounds 1 and 2 (each within the scatter of the next).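

Swapping ethyl for vinyl on this chain gives, in this assay, a 3.9-fold lower number from compound 2 to compound 3 (0.59 log units; beyond the scatter) as the first reading of this change on its own. This shows that the position responds to the swap: both groups count 2 heavy atoms, and the one difference is a double bond outside aromatic rings. Among the compounds shown here, compound 1 carries the same (but-3-en-1-yl)oxy group but also differs from compound 3 elsewhere, so only the pair of compound 2 and compound 3 isolates this change.

Going by these compounds, it remains open whether an ethynyl group or a longer chain ending in vinyl would move the number further in the same direction. On these data alone, it is also open whether the same swap would have a similar effect on a different core. Nothing measured here explains the drop.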